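A few compounds are considered here, and "the series" means these few. Any claim that something is new, unique, unknown or untested is made for them only; others in the source may bear on it.

Measured in a functional assay on A549 cells (Homo sapiens) for inhibition, read by sulforhodamine B assay; on this read-out lower numbers stand for stronger inhibition and higher numbers for weaker inhibition:

- Compound 1 `COC(=O)CC/C(C)=C/Cc1c(OC)c(C)c2c(c1OCC#CCN1CCN(c3ccc(O)cc3)CC1)C(=O)OC2`: > 50000 nM (a limit)
- Compound 2 `COC(=O)CC/C(C)=C/Cc1c(OC)c(C)c2c(c1OCC#CCN1CCN(c3ccccc3OC)CC1)C(=O)OC2`: > 50000 nM (a limit)
- Compound 3 `COC(=O)CC/C(C)=C/Cc1c(OC)c(C)c2c(c1OCC#CCN1CCC(Cc3ccccc3)CC1)C(=O)OC2`: 40700 nM

Within the data shown here, compound 3, at 40700 nM, gives the only true number in this small set. Compound 1 gives > 50000 nM, which is a limit of the assay and not a number. Compound 2 gives > 50000 nM, which is also a limit. The measurements therefore show (the limit of > 50000 nM in this assay, at which 2 of the 3 values shown sit).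

The next compound, compound 4 `COC(=O)CC/C(C)=C/Cc1c(OC)c(C)c2c(c1OCC#CCN1CCC(C(=O)OC)CC1)C(=O)OC2`, has methoxycarbonyl in place of benzyl on a saturated ring carbon.

Among the measured compounds shown here, the only step between measured compounds is a step that the two limits leave unreadable from compound 1 to compound 2. It involves a different part of the structure, and its size cannot be read, so it offers no size to carry over to this change. The expectation therefore rests on compound 3, which gives 40700 nM. It also rests on the limit reached by the other two compounds. No step beyond the usual scatter is expected in this assay, and no clear gain in inhibition is foreseen. The estimated step is a 1.2-fold higher number from compound 3 to compound 4 (0.09 log units; within the scatter). A report of only a limit would be no surprise. For compound 4 the estimated value is 50000 nM, with an expected range from 22000 nM to 110000 nM.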

Compound 4, half-maximal inhibitory concentration: 40500 nM
Compound 4: middle estimate off by 1.2-fold (0.09 log units), on the high side, within the range that was stated.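

In this assay, methoxycarbonyl in place of benzyl on the saturated ring carbon gives a 1.0-fold lower number from compound 3 to compound 4 (0.00 log units; within the scatter). Among these compounds, this is the first step in the set that can be read, and it shows that at this position, three ring bonds from the ring nitrogen, the read-out does not move beyond the scatter when a six-membered aromatic ring of carbon leaves and a group with 2 hydrogen-bond acceptors and fewer heavy atoms enters. It cannot be taken to mean that the position plays no part in inhibition, since the two numbers that can be read lie close to the ceiling of what this read-out can report: the limit of > 50000 nM in this assay, at which 2 of the 4 values shown sit.

As far as these compounds go, whether a carboxylic acid or an aminomethyl group on this ring carbon would shift the number beyond the scatter remains open. Also open, from the compounds shown here alone, is whether a longer chain ending in a phenyl ring, or a hydroxymethyl group, would bring the number well down from this level of weak inhibition.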